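Aryl versus alkyl hydrazone arms in a nucleoside series

The source may report more compounds than this note shows. Statements on the series, on what has been measured and on what is new or still open speak of the compounds shown alone.

Compound 2 `CSCC/C=N/Nc1nc(N)c2ncn([C@@H]3O[C@H](CO)[C@@H](O)[C@H]3O)c2n1` carries a 2-(methylsulfanyl)ethyl arm on the hydrazone carbon. In an assay on CHO-K1 cells for displacement of a labelled ligand from adenosine receptor A1 (Homo sapiens), read by scintillation counting, with a stated time of 60 min (a lower number here means a stronger inhibitor, a higher number a weaker inhibitor), compound 2 reaches only the limit of the assay, > 10000 nM (the limit of > 10000 nM in this assay, at which 1 of the 2 values shown sits). Compound 1 `Nc1nc(N/N=C/c2cncs2)nc2c1ncn2[C@@H]1O[C@H](CO)[C@@H](O)[C@H]1O`, the 1,3-thiazol-5-yl analogue, gives 22 nM in this assay, and the change an at least 450-fold higher number from compound 1 to compound 2 (2.65 log units; beyond the scatter). Compound 3 `N#Cc1ccccc1/C=N/Nc1nc(N)c2ncn([C@@H]3O[C@H](CO)[C@@H](O)[C@H]3O)c2n1` differs from compound 2 by 2-cyanophenyl in place of 2-(methylsulfanyl)ethyl on a carbon with a double bond to nitrogen, restoring an aromatic ring on that carbon. Going by the values given here, only that one measured step bears on this change, and it was large. A large step in the opposite direction is therefore expected: an at least 66-fold lower number from compound 2 to compound 3 (1.82 log units; beyond the scatter). Compound 3 is estimated at 150 nM, range 20 nM to 3000 nM.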

Compound 3, inhibition constant: 2.9 nM
For compound 3 the middle estimate is 52-fold (1.71 log units) above the measured one; the whole stated range lies above it.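

The aromatic ring on a carbon with a double bond to nitrogen need not be 1,3-thiazol-5-yl: in this assay 2-cyanophenyl in its place gives a 7.6-fold lower number from compound 1 to compound 3 (0.88 log units; beyond the scatter). Against the alkyl arm, the change gives an at least 3400-fold lower number from compound 2 to compound 3 (3.53 log units; beyond the scatter). Compound 2 is a limit, so that step is only a bound: the limit of > 10000 nM in this assay, at which 1 of the 3 values shown sits.

From the compounds shown here alone, what the nitrile contributes stays open; a plain phenyl on that carbon would separate it from the ring. Going by these compounds, whether the loss belongs to alkyl arms generally or to 2-(methylsulfanyl)ethyl alone also stays open, and a cyclohexyl ring or a butyl chain would bear on that.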